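Compound 3 and the Exchange of an Aryl Group

A few compounds are considered here, and "the series" means these few. Any claim that something is new, unique, unknown or untested is made for them only; others in the source may bear on it.

In an ADME assay on MT4 cells (Homo sapiens) for cytotoxicity, read by MTT assay (on this read-out higher numbers stand for lower toxicity in this test and lower numbers for higher toxicity in this test), compound 1 `Cc1ccc(N(C(=O)c2cccc([N+](=O)[O-])c2)C(=S)OCCN2C(=O)c3ccccc3C2=O)cc1` gives 100000 nM and compound 2 `Cc1ccc(N(C(=O)c2ccc(Cl)c([N+](=O)[O-])c2)C(=S)OCCN2C(=O)c3ccccc3C2=O)cc1` gives 47000 nM as the lower of the two numbers. Among the measured compounds shown here, compound 3 `Cc1ccc(N(C(=O)c2ccc(Br)c(C)c2)C(=S)OCCN2C(=O)c3ccccc3C2=O)cc1` has 4-bromo-3-methylphenyl in place of 4-chloro-3-nitrophenyl on a carbonyl carbon and no measured step covers that whole change. Only the modest step of a 2.1-fold lower number from compound 1 to compound 2 (0.33 log units; beyond the scatter) with chloro in place of hydrogen on an aromatic carbon bears on it, so a change of similar size at most is expected, its direction open. The estimated step of a 1.2-fold lower number from compound 2 to compound 3 (0.07 log units; within the scatter) is accordingly small. Compound 3 is expected at 40000 nM with a range from 12000 nM to 100000 nM as the estimate.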

Compound 3, half-maximal cytotoxic concentration: > 100000 nM
Compound 3: only a limit was reported; the forecaster's own chance of this, stated with the estimate: 25%; middle value at least 2.5-fold (0.39 log units) away from the limit.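

With 4-bromo-3-methylphenyl in place of 4-chloro-3-nitrophenyl on a carbonyl carbon, this assay shows an at least 2.1-fold higher number from compound 2 to compound 3 (0.32 log units; beyond the scatter), so the change at this place moves the number toward lower toxicity in this test, whereas the earlier step, a 2.1-fold lower number from compound 1 to compound 2 (0.33 log units; beyond the scatter), ran toward higher toxicity. For compound 3 the reading is a limit, not a number: > 100000 nM. The remaining step can be given only as a number no lower from compound 1 to compound 3 (the limit leaves the size open), and its size cannot be read, because the reading sits at that limit: the limit of > 100000 nM in this assay, at which 1 of the 3 values shown sits.

The compounds shown do not separate the effect of the bromo group from that of the methyl group. As far as these compounds go, how an amine or a carboxylic acid on this phenyl group would read also stays open.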